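This account rests on a few compounds, and the source may have more. Where it says the series, first, only, none or still open, it means among the compounds named here.

Going by the values given here, in a functional assay on blood (Homo sapiens), with a stated time of 60 min, in the presence of a further agent that is not named here (on this read-out lower numbers stand for an effect already at smaller amounts and higher numbers for an effect only at larger amounts of compound), compound 2 `O=C(Oc1ccccc1)C1(S(=O)(=O)c2ccc(Oc3ccc(OC(F)(F)F)cc3)cc2)CCC2(CCNCC2)C1` gives 900 nM, the only plain number among the two values shown. Compound 1 `COC(=O)C1(S(=O)(=O)c2ccc(Oc3ccc(OC(F)(F)F)cc3)cc2)CCC2(CCNCC2)C1` reaches only a limit of this assay, > 15000 nM. Between them stands one measured step, an at least 16-fold lower number from compound 1 to compound 2 (1.22 log units; beyond the scatter), which rests on that limit (the limit of > 15000 nM in this assay, at which 1 of the 2 values shown sits). Compound 3 `O=C(Oc1ccccc1)C1(S(=O)(=O)c2ccc(NC3CCCCC3)cc2)CCC2(CCNCC2)C1` differs from compound 2 in another place: cyclohexylamino in place of 4-(trifluoromethoxy)phenoxy on an aromatic carbon. Among the compounds with values here, no measured step touches this change, so the single known step offers no guide to its size or direction. Compound 3 is therefore expected to come out near 1500 nM, within 400 nM to 6000 nM. The implied expected step is a 1.7-fold higher number from compound 2 to compound 3 (0.22 log units; within the scatter).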

Compound 3, half-maximal effective concentration: > 15000 nM
Compound 3 gave a limit, no number (the forecaster's own chance of this, stated with the estimate: 15%); at least 10-fold (1.00 log units) between middle value and limit.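

In this assay, the place on the aromatic carbon, para to a large group, proves sensitive to change: cyclohexylamino in place of 4-(trifluoromethoxy)phenoxy gives an at least 16-fold higher number from compound 2 to compound 3 (1.22 log units; beyond the scatter). The phenyl ester shared by compound 2 and compound 3 is thus not enough on its own to give a number in this assay. Compound 3 stands at a limit, so the step gives only a minimum: the limit of > 15000 nM in this assay, at which 2 of the 3 values shown sit.

Which part of the departing group counts stays open, with the aromatic ring, the linking oxygen and the trifluoromethoxy group all leaving together in compound 3. Also open, as far as these compounds go, is how a plain phenoxy, a phenylamino or a cyclohexyloxy group would read at this place.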